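The source may hold more compounds than are shown below. What is called first, only, known or untested is meant among the compounds shown, and "the series" means these compounds.

In a functional assay on L5178Y cells (Mus musculus) for cytotoxicity, read by MTT assay (a higher number here means a weaker inhibitor, a lower number a stronger inhibitor), compound 3 `CC(C)(C)c1ccc(OCCCCN2CCN(c3ccccn3)CC2)cc1` gives 15.1 nM. That places it level with compound 2 `CCC(C)(C)c1ccc(OCCCCN2CCN(c3cnccn3)CC2)cc1`, which gives 12.6 nM, since these two numbers lie within the scatter of each other. Compound 1 `CC(=O)c1ccc(OCCCCN2CCN(c3ccccn3)CC2)cc1` stands clearly higher at 63.7 nM. Among the compounds with values here, the one measured step in the set is a 4.2-fold lower number from compound 1 to compound 3 (0.63 log units; beyond the scatter). It lies beyond the scatter, but it concerns tert-butyl in place of acetyl on an aromatic carbon and not the part of the molecule that changes next.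

Compound 4 `CC(C)(C)c1ccc(OCCCCN2CCN(c3cnccn3)CC2)cc1` has not yet been measured. Its difference from compound 3 is pyrazin-2-yl in place of pyridin-2-yl on an amine nitrogen in a ring, which amounts to pyrazin-2-yl in place of pyridin-2-yl on an amine nitrogen in a ring. Within the data shown here, no measured step isolates this exchange, so the size of its effect cannot be read directly from the data. Set against compound 3, the nearest evidence is compound 2, which carries pyrazin-2-yl with a different alkyl group and gives 12.6 nM. Compound 4 keeps the tert-butyl group of compound 3, so the only expectation the data support in this assay is no change beyond the scatter. The expected step is a 1.1-fold lower number from compound 3 to compound 4 (0.03 log units; within the scatter). Compound 4 is therefore estimated at 14 nM, with an expected range of 7 nM to 28 nM.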

Compound 4, half-maximal inhibitory concentration: 18.3 nM
Compound 4: the middle estimate sits 1.3-fold (0.12 log units) below what was measured; measured number inside the range.
By their numbers in this assay, from the lowest: compounds 2, 3 and 4 (each within the scatter of the next); then compound 1.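

With tert-butyl held fixed, this assay now gives a direct reading of this exchange on the amine nitrogen in a ring: pyrazin-2-yl in place of pyridin-2-yl, a ring with 2 hetero atoms and 2 hydrogen-bond acceptors for one with 1 of each, produces a 1.2-fold higher number from compound 3 to compound 4 (0.08 log units; within the scatter) and so makes no difference that can be told from scatter at this place. The second new step, a 1.5-fold higher number from compound 2 to compound 4 (0.16 log units; within the scatter) for hydrogen in place of methyl on a saturated chain carbon, two bonds along the chain from an aromatic carbon, shows that with pyrazin-2-yl present this small change in the alkyl group also stays within the scatter. No other measurement is available that could account for either result.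

Going by these compounds, it remains open whether pyrazin-2-yl would be equally silent alongside the acetyl group of compound 1 at 63.7 nM in this assay, where the number stands clearly higher. Also open, on these data alone, is how a phenyl or pyrimidin-2-yl group on the same nitrogen, or a longer chain linking the two halves of the molecule, would read here.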